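The source may hold more compounds than are shown below. What is called first, only, known or untested is meant among the compounds shown, and "the series" means these compounds.

Working notes on the series, values in a functional assay on WM 266-4 cells (Homo sapiens) for inhibition, read by MTT assay, with a stated time of 24 h; a lower number here means a stronger inhibitor of growth, a higher number a weaker inhibitor of growth:

- compound 1 `O=C(C1COc2ccccc2O1)N1N=C(c2ccc(Br)cc2)CC1c1cccc(F)c1`: 7810 nM
- compound 2 `O=C(C1COc2ccccc2O1)N1N=C(c2ccccc2)CC1c1cccc(F)c1`: 1450 nM
- compound 3 `O=C(c1ccc2c(c1)OCCO2)N1N=C(c2ccccc2)CC1c1cccc(F)c1`: 1840 nM

Compound 2 holds the lowest number of the three in this assay. Its nearest neighbour is compound 3, with a 1.3-fold higher number from compound 2 to compound 3 (0.10 log units; within the scatter); its furthest is compound 1, with a 5.4-fold lower number from compound 1 to compound 2 (0.73 log units; beyond the scatter).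

Compound 4 `O=C(C1COc2ccccc2O1)N1N=C(c2ccccc2)CC1c1ccccc1F` keeps every atom of compound 2 and differs only in how they are joined: 2-fluorophenyl in place of 3-fluorophenyl on a saturated ring carbon. Neither measured step touches the fluorophenyl on the saturated ring carbon; one removes a bromo, the other reattaches the dioxin to the carbonyl. With nothing that bears directly on this change, the expected step is a 1.2-fold higher number from compound 2 to compound 4 (0.09 log units; within the scatter), within the scatter. Compound 4 is therefore estimated at 1800 nM, range 700 nM to 4500 nM.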

Compound 4, concentration for 50% growth inhibition: 1490 nM
For compound 4 the middle estimate is 1.2-fold (0.08 log units) above the measured one; the measured number falls inside the stated range.
By their numbers in this assay, from the lowest: compounds 2, 4 and 3 (each within the scatter of the next); then compound 1.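

Of the steps shown, this is the only one that touches the fluorophenyl on the saturated ring carbon: in this assay 2-fluorophenyl in place of 3-fluorophenyl gives a 1.0-fold higher number from compound 2 to compound 4 (0.01 log units; within the scatter) and stays within the scatter. Compound 2 and compound 4 therefore cannot be told apart in this read-out, so this placement of the fluorine leaves the number in place. No measurement shown here offers an explanation for this result.

Still open, going by these compounds, is whether a methoxy, a hydroxyl or an amine on this phenyl would move the number beyond the scatter. Also open, on these data alone, is whether a bromo on the other phenyl would carry the same penalty alongside 2-fluorophenyl.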